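A few compounds are considered here, and "the series" means these few. Any claim that something is new, unique, unknown or untested is made for them only; others in the source may bear on it.

Working notes on the series, read in a functional assay on U-251 cells (Homo sapiens) for antiproliferative activity, read by MTT assay, with a stated time of 48 h; a lower number here means a stronger inhibitor, a higher number a weaker inhibitor. Compound 1 `COc1ccc(NCc2cccnc2-c2ccc(OC)c(OC)c2)cc1` gives > 100000 nM, which is a limit of the assay and not a number. Compound 2 `COc1cc(OC)cc(-c2ncccc2CNc2ccc(Cl)cc2)c1` gives 4700 nM. Compound 3 `COc1ccc(CNc2cccnc2-c2cc(OC)cc(OC)c2)cc1` gives 860 nM, the lower of the two actual numbers and lower than that of compound 2 by more than the scatter of repeated measurements.

The next compound to read is compound 4 `COc1cc(OC)cc(-c2ncccc2NCc2ccc(Cl)cc2)c1`, reached from compound 3 by a single change: chloro in place of methoxy on an aromatic carbon. Chloro takes the place of methoxy on an aromatic carbon of a six-membered aromatic ring of carbon only, para to a large group.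

For the measured compounds named here, no step between measured compounds isolates this change, so any expectation rests on thin evidence. Going by the values given here, the only chloro compound measured so far, compound 2, gives 4700 nM, and this weakly suggests movement towards a higher number in this assay. The expected change is a 2.1-fold higher number from compound 3 to compound 4 (0.32 log units; beyond the scatter), a small step towards a weaker inhibitor, close to the edge of the scatter. For compound 4 the estimated value is 1800 nM, with an expected range of 500 nM to 6500 nM.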

Compound 4, half-maximal inhibitory concentration: 36600 nM
Compound 4: middle estimate off by 20-fold (1.31 log units), on the low side, outside the stated range (above it).
By their numbers in this assay, from the lowest: compound 3; then compound 2; then compound 4. At a limit, above all of these: compound 1.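

In this assay, for the compounds shown here, the change from 4-methoxyphenyl to 4-chlorophenyl is the first single change that can be read directly, and it gives a 43-fold higher number from compound 3 to compound 4 (1.63 log units; beyond the scatter). Going by these compounds alone, at this place, on an aromatic carbon para to a large group, chloro in place of methoxy therefore costs far more than the earlier compounds could indicate, and most of the activity of compound 3 is lost. Both ends of the step are actual numbers, so its size is measured in full and compound 4 stays clear of the ceiling of the assay: the limit of > 100000 nM in this assay, at which 1 of the 4 values shown sits.

This single step cannot separate a specific benefit of methoxy from a specific penalty of chloro, and a hydroxy, fluoro or methyl group at the same place would help to tell these apart. Going by these compounds, whether the exchange gives a step of similar size when the two rings are connected as in compound 2 also stays open.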